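Chloro for methyl: from compound 3 to compound 4

This account rests on a few compounds, and the source may have more. Where it says the series, first, only, none or still open, it means among the compounds named here.

Values in a functional assay on MCF7 cells (Homo sapiens) for antiproliferative activity, read by MTT assay, with a stated time of 48 h; on this read-out lower numbers stand for stronger inhibition and higher numbers for weaker inhibition:
- compound 1 `Cc1ccc(S(=O)(=O)NC(=O)c2cccnc2)cc1`: 12000 nM
- compound 2 `O=C(NS(=O)(=O)c1ccc(F)cc1)c1cncc(Br)c1`: 980 nM
- compound 3 `Cc1ccc(S(=O)(=O)NC(=O)c2ccc(Cl)nc2)cc1`: 17200 nM

Compound 3, at 17200 nM, stands with compound 1 at the high end of these numbers, and compound 2 lies well below both. Compound 4 `O=C(NS(=O)(=O)c1ccc(Cl)cc1)c1ccc(Cl)nc1` differs from compound 3 in one place: chloro in place of methyl on an aromatic carbon. For the measured compounds named here, no measured step covers this change. The only one, a 1.4-fold higher number from compound 1 to compound 3 (0.16 log units; within the scatter), concerns chloro at another place and stays within the scatter. Compound 2, which lacks the methyl, gives 980 nM, but it also differs from compound 3 elsewhere, so that gap cannot be assigned to this change. A moderate move toward a lower number in this assay is expected, an estimated 2.9-fold lower number from compound 3 to compound 4 (0.46 log units; beyond the scatter). For compound 4 the estimated value is 6000 nM, with an expected range of 1500 nM to 20000 nM.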

Compound 4, half-maximal inhibitory concentration: 8070 nM
The estimate for compound 4 lay 1.3-fold (0.13 log units) below the measured number; measured number inside the range.
By their numbers in this assay, from the lowest: compound 2; then compounds 4, 1 and 3 (each within the scatter of the next, the first and the last beyond it).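

In this assay, this place on the aromatic ring, para to a large group, shows a modest response to the exchange of methyl for chloro: a 2.1-fold lower number from compound 3 to compound 4 (0.33 log units; beyond the scatter). The earlier step, a 1.4-fold higher number from compound 1 to compound 3 (0.16 log units; within the scatter), concerned chloro at another place and stayed within the scatter, so this is the only step shown that goes beyond it. Nothing shown gives a reason for this step. Still open, going by these compounds, is how a methoxy group or an amine at this place would compare with methyl and chloro. On these data alone, it is also open whether the step holds in compounds without the second chloro.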